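Swapping the ring-nitrogen group: compound 3 to compound 4

The source may hold more compounds than are shown below. What is called first, only, known or untested is meant among the compounds shown, and "the series" means these compounds.

In an ADME assay on MT4 cells (Homo sapiens) for cytotoxicity, read by MTT assay, with a stated time of 5 days (on this read-out higher numbers stand for lower toxicity in this test and lower numbers for higher toxicity in this test), compound 1 (`Cc1cc(C)cc(S(=O)(=O)c2c(C(=O)NC3CNC3)[nH]c3ccc(Cl)cc23)c1`) gives 37300 nM as a measured number. Compound 2 (`Cc1cc(C)cc(S(=O)(=O)c2c(C(=O)NC3CN(Cc4ccccc4C#N)C3)[nH]c3ccc(Cl)cc23)c1`) gives > 234000 nM as a limit of the assay. Going by these compounds, compound 3 (`Cc1cc(C)cc(S(=O)(=O)c2c(C(=O)NC3CN(S(C)(=O)=O)C3)[nH]c3ccc(Cl)cc23)c1`) stands at > 252000 nM as a limit too, so its true position is unknown. Compound 4 (`Cc1cc(C)cc(S(=O)(=O)c2c(C(=O)NC3CN(Cc4ccccc4F)C3)[nH]c3ccc(Cl)cc23)c1`) carries 2-fluorobenzyl in place of methylsulfonyl on an amine nitrogen in a ring. The closest evidence is an at least 6.2-fold higher number from compound 1 to compound 2 (0.79 log units; beyond the scatter) with 2-cyanobenzyl on that nitrogen, and an at least 6.7-fold higher number from compound 1 to compound 3 (0.82 log units; beyond the scatter) with methylsulfonyl there. Both lie beyond the scatter, and both end at limits. No step beyond the scatter is therefore expected in this assay, and the estimate is an at least 1.2-fold lower number from compound 3 to compound 4 (0.10 log units; that floor lies within the scatter) as the expected change. For compound 4 the expected value is 200000 nM with 70000 nM to 260000 nM as its range.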

Compound 4, half-maximal cytotoxic concentration: > 238000 nM
Compound 4 gave a limit, no number (the forecaster's own chance of this, stated with the estimate: 60%); at least 1.1-fold (0.07 log units) between middle value and limit.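

In this assay, 2-fluorobenzyl on the amine nitrogen gives an at least 6.3-fold higher number from compound 1 to compound 4 (0.80 log units; beyond the scatter). Among these compounds, a third group on that nitrogen therefore joins the compounds that show no number, while compound 1, with hydrogen there, remains the only measured value. Compound 4 ends at a limit, and the steps among compound 2, compound 3 and compound 4 cannot be read: the limit of > 238000 nM in this assay, at which 1 of the 4 values shown sits.

Where the true values of these three compounds lie stays open. Also open, going by these compounds, is whether a small methyl or a chain ending in a carboxylic acid on that nitrogen would likewise end at a limit.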